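Replacing the Pyrazole Ring of Compound 2 with Methylcarbamoyl

The compounds below may be only part of what the source reports. "The series", "measured", "known", "first", "only" and "open" are said of these compounds alone.

Compound 1 `CC(C)Oc1cc(-c2cncc(-c3cnn(C(C)C)c3)c2)ccc1C(N)=O` and compound 2 `CC(C)Oc1cc(-c2cncc(-c3cnn(C)c3)c2)ccc1C(N)=O` share one core and differ only in the group on the aromatic nitrogen. In an assay on cells for inhibition of MAP kinase-interacting serine/threonine-protein kinase 1 (Homo sapiens), read by mobility shift assay, with stated times of 10 min and 60 min, in the presence of a further agent that is not named here (a lower number here means a stronger inhibitor, a higher number a weaker inhibitor), compound 1 gives 85 nM, while compound 2 gives 400 nM, the higher of the two numbers; the step of a 4.7-fold higher number from compound 1 to compound 2 (0.67 log units; beyond the scatter) shows that the change to methyl weakened inhibition. Compound 3 `CNC(=O)c1cncc(-c2ccc(C(N)=O)c(OC(C)C)c2)c1` goes further: methylcarbamoyl in place of 1-methyl-1H-pyrazol-4-yl on an aromatic carbon. For the measured compounds named here, no measured step covers this exact exchange, so the single known step is only a hint. Because a 4.7-fold higher number from compound 1 to compound 2 (0.67 log units; beyond the scatter) already pointed toward weaker inhibition, compound 3 is expected to be weaker still, by about a 3.8-fold higher number from compound 2 to compound 3 (0.57 log units; beyond the scatter). The estimate for compound 3 is 1500 nM, with a range from 400 nM to 6000 nM.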

Compound 3, half-maximal inhibitory concentration: 1900 nM
For compound 3 the middle estimate is 1.3-fold (0.10 log units) below the measured one, within the range that was stated.
By their numbers in this assay, from the lowest: compound 1; then compound 2; then compound 3.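

In this assay, this position responds not only to the group on the pyrazole nitrogen but also to loss of the whole ring: open-chain methylcarbamoyl in place of 1-methyl-1H-pyrazol-4-yl gives a 4.8-fold higher number from compound 2 to compound 3 (0.68 log units; beyond the scatter) and weakens inhibition. Measured against the isopropyl-bearing ring, the same group gives a 22-fold higher number from compound 1 to compound 3 (1.35 log units; beyond the scatter) and leaves a large loss. Nothing available explains these losses.

As far as these compounds go, whether a ring is needed here remains open. So does how an amine, a carboxylic acid or a longer chain at this position would compare.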